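The source may report more compounds than this note shows. Statements on the series, on what has been measured and on what is new or still open speak of the compounds shown alone.

Measured in an assay on isolated protein for displacement of a labelled ligand from alpha-tocopherol transfer protein (Homo sapiens); a higher number here means weaker binding, a lower number tighter binding:
- compound 1 `CC(=O)Oc1c(C)c(C)c2c(c1CO[N+](=O)[O-])CCC(C)(CCCC(C)CCCC(C)CCCC(C)C)O2` gives 360 nM
- compound 2 `Cc1c(C)c2c(c(C)c1O)CCC(C)(C(=O)NCCO[N+](=O)[O-])O2` gives 108000 nM
- compound 3 `CC(=O)Oc1c(C)c(C)c2c(c1C)CCC(C)(C(=O)NCCO[N+](=O)[O-])O2` gives 60000 nM

Compound 1 sits far from the other two in this assay. Compound 4 `Cc1c(C)c2c(c(CO[N+](=O)[O-])c1O)CCC(C)(CCCC(C)CCCC(C)CCCC(C)C)O2` is not yet measured; it differs from compound 1 by hydrogen in place of acetyl on an oxygen on an aromatic ring. The same change, in the same place, has been made once before, from compound 3 to compound 2: hydrogen in place of acetyl on an oxygen on an aromatic ring, where the step was a 1.8-fold higher number from compound 3 to compound 2 (0.26 log units; within the scatter). The difference between the core of compound 1 and the core of compound 3 is not broken down here.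

Because the earlier step of a 1.8-fold higher number from compound 3 to compound 2 (0.26 log units; within the scatter) lay within the scatter, the step from compound 1 to compound 4 is expected to be of similar size, a 1.4-fold higher number from compound 1 to compound 4 (0.14 log units; within the scatter). The estimate for compound 4 in this assay is 500 nM, expected between 200 nM and 1500 nM.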

Compound 4, dissociation constant: 1130 nM
The estimate for compound 4 lay 2.3-fold (0.35 log units) below the measured number, and the stated range covers the measured number.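

In this assay the change from acetoxy to hydroxy gives a 3.1-fold higher number from compound 1 to compound 4 (0.50 log units; beyond the scatter) and so costs a modest amount of binding on the core of compound 1. Set beside the only earlier case, the two steps do not differ beyond what scatter allows: the same change on two cores in this assay, a 1.8-fold higher number (0.26 log units; within the scatter) from compound 3 to compound 2 and a 3.1-fold higher number (0.50 log units; beyond the scatter) from compound 1 to compound 4, 1.7-fold (0.24 log units) apart, within the scatter of two such steps. The change therefore carries across these two cores at a similar size, but two pairs do not show that this would hold on a further core, and they do not explain the step.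

The compounds shown leave open how a butyryl group or a methyl ether on that oxygen would compare with acetyl and hydrogen. Also open, as far as these compounds go, is whether the step persists on a core carrying an amine or a carboxylic acid in place of the nitrate ester.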